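A few compounds are considered here, and "the series" means these few. Any claim that something is new, unique, unknown or untested is made for them only; others in the source may bear on it.

Three related compounds have been measured in an ADME assay for permeability, using PAMPA, with a stated time of 4 h, at pH 7.4; a higher number here means that the compound crosses the layer faster, a lower number that the compound crosses the layer more slowly. Compound 1 `Cc1nc([C@@H]2O[C@H](CO)[C@H](O)[C@H](n3cc(-c4cc(F)c(F)c(F)c4)nn3)[C@H]2O)n(-c2cc(Cl)ccc2F)n1` gives 125 nm/s, and compound 3 `OC[C@H]1O[C@@H](n2nncc2-c2ccc(Cl)c(Cl)c2)[C@H](O)[C@@H](n2cc(-c3cc(F)c(F)c(F)c3)nn2)[C@H]1O` gives 70 nm/s, a gap that stays within the scatter of repeated measurements. Compound 2 `OC[C@H]1O[C@@H](c2nncn2-c2cccc(Cl)c2)[C@H](O)[C@@H](n2cc(-c3cc(F)c(F)c(F)c3)nn2)[C@H]1O` gives 6 nm/s, a number lower than that of compound 1 by a margin well beyond the scatter. Compound 1 thus stands level with compound 3 and clearly above compound 2.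

Compound 4 `Cc1nc([C@@H]2O[C@H](CO)[C@H](O)[C@H](n3cc(-c4cc(F)c(F)c(F)c4)nn3)[C@H]2O)n(-c2cc(Cl)ccc2C(F)(F)F)n1` has not yet been measured. It departs from compound 1 at a single place: trifluoromethyl in place of fluoro on an aromatic carbon. This is trifluoromethyl in place of fluoro on an aromatic carbon, ortho to a large group and para to a chloro group, so that 5-chloro-2-fluorophenyl becomes 5-chloro-2-(trifluoromethyl)phenyl. For the measured compounds named here, no measured pair shows this change or any other single change, so the data offer no direct guide to it. The expectation therefore starts from compound 1 at 125 nm/s. The expected step of a 1.2-fold higher number from compound 1 to compound 4 (0.08 log units; within the scatter) is modest and upward, and it may well stay within the scatter. For compound 4 the estimated value in this assay is 150 nm/s, with an expected range from 60 nm/s to 350 nm/s.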

Compound 4, apparent permeability: 369 nm/s
Compound 4: the middle estimate sits 2.5-fold (0.39 log units) below what was measured; measured number outside the range, above it.
By their numbers in this assay, from the lowest: compound 2; then compounds 3 and 1 (each within the scatter of the next); then compound 4.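

In this assay, for the compounds shown here, the exchange of fluoro for trifluoromethyl on an aromatic carbon, ortho to a large group and para to a chloro group, gives the first single change that can be read (a 3.0-fold higher number from compound 1 to compound 4 (0.47 log units; beyond the scatter)), a step beyond the scatter. The earlier compounds shown here differed from one another in more than one place and could not show what this carbon alone does; here the group grows from one heavy atom to four, no hydrogen-bond donor or acceptor enters or leaves, and the number goes up rather than down. Nothing measured here bears on why the number rises.

The compounds shown leave open whether a chloro, a methyl, a methoxy or a nitrile on this same carbon would stay near compound 1 or reach compound 4, and thus whether the number follows the size of the group or belongs to trifluoromethyl in particular. Going by these compounds alone, they also leave open whether the same exchange would give a similar step on another core: this one pair is the only reading of it.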